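The compounds below may be only part of what the source reports. "The series", "measured", "known", "first", "only" and "open" are said of these compounds alone.

Compound 1, `CC(NC(=O)c1ccc(C(C)(C)C)cc1)c1ccc(C(=O)O)cc1`, and compound 2, `CC(C)(C)c1ccc(C(=O)NCc2ccc(S(N)(=O)=O)cc2)cc1`, share the same core and were both examined in an assay on HeLa cells with Bile acid receptor (Homo sapiens) as the target, read by a luciferase reporter, with a stated time of 24 h; on this read-out lower numbers stand for an effect already at smaller amounts and higher numbers for an effect only at larger amounts of compound. There compound 1 gives 76 nM, while compound 2 gives 1400 nM. Of these two numbers compound 2 therefore stands at the higher one, and the gap between it and compound 1 is wide enough to lie beyond the scatter of the measurement.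

Compound 3, `CC(C)(C)c1ccc(C(=O)NCc2ccc(OCC(=O)O)cc2)cc1`, follows from compound 2 by a single exchange: carboxymethoxy in place of sulfamoyl on an aromatic carbon. Because compound 1 gives 76 nM in this assay, the exchange in compound 3 is expected to bring the number down, and the step of a 4.7-fold lower number from compound 2 to compound 3 (0.67 log units; beyond the scatter) is estimated to be larger than the scatter. For compound 3 the estimated value in this assay is 300 nM, expected to fall between 80 nM and 1200 nM.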

Compound 3, half-maximal effective concentration: 730 nM
Compound 3: middle estimate off by 2.4-fold (0.39 log units), on the low side, and the stated range covers the measured number.
By their numbers in this assay, from the lowest: compound 1; then compounds 3 and 2 (each within the scatter of the next).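

At this place, on an aromatic carbon para to a large group, carboxymethoxy in place of sulfamoyl gives a 1.9-fold lower number from compound 2 to compound 3 (0.28 log units; within the scatter) in this assay. Going by these compounds alone, this is the first single-place step, and it shows that the exchange, which keeps the same counts of hydrogen-bond donors and acceptors, does not separate the two compounds on this read-out. Nothing available accounts for this result.

The compounds shown leave open whether another group at this place, such as an amine, a nitrile or a longer chain ending in a carboxylic acid, would move the number beyond the scatter. Compound 1, at 76 nM, differs from compound 3 in more than one place, so its value cannot be tied to any single change.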